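A Methyl Added to a Saturated Ring in Two Series

The source may hold more compounds than are shown below. What is called first, only, known or untested is meant among the compounds shown, and "the series" means these compounds.

Compound 1 `COc1cc2c(Oc3ccc(NC(=O)c4nnn(-c5ccccc5)c4C)cc3F)ccnc2cc1OCCCN1CCCCC1` and compound 3 `COc1cc2c(Oc3ccc(NC(=O)c4nnn(-c5ccccc5)c4C)cc3F)ccnc2cc1OCCCN1CCC(C)CC1` share one core and differ only by methyl in place of hydrogen on a saturated ring carbon. In a functional assay on NCI-H460 cells (Homo sapiens) for cytotoxicity, read by MTT assay, with a stated time of 72 h (a lower number here means a stronger inhibitor, a higher number a weaker inhibitor), compound 1 gives 220 nM and compound 3 gives 170 nM, a step of a 1.3-fold lower number from compound 1 to compound 3 (0.11 log units; within the scatter). Compound 2 `COc1cc2c(Oc3ccc(NC(=O)c4nnn(-c5ccc(F)cc5)c4C(F)(F)F)cc3F)ccnc2cc1OCCCN1CCCCC1` rests on a different core; the difference between the two cores is not broken down here. In this assay compound 2 gives 190 nM. Compound 4 `COc1cc2c(Oc3ccc(NC(=O)c4nnn(-c5ccc(F)cc5)c4C(F)(F)F)cc3F)ccnc2cc1OCCCN1CCC(C)CC1` arises from compound 2 by the same change, (methyl in place of hydrogen on a saturated ring carbon), with the place described in identical words. Because the step of a 1.3-fold lower number from compound 1 to compound 3 (0.11 log units; within the scatter) lay within the scatter, a step of similar size is expected here, namely a 1.3-fold lower number from compound 2 to compound 4 (0.10 log units; within the scatter). Compound 4 is therefore estimated at 150 nM, with a likely range from 75 nM to 320 nM.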

Compound 4, half-maximal inhibitory concentration: 190 nM
Compound 4: middle estimate off by 1.3-fold (0.10 log units), on the low side; low and high end bracket the measured number.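

In this assay the change from piperidin-1-yl to 4-methylpiperidin-1-yl, carried onto the core of compound 2, gives no change at the digits printed from compound 2 to compound 4 (within the scatter). Set beside the earlier step, it shows no difference between the two cores beyond the scatter: the same change on two cores in this assay, a 1.3-fold lower number (0.11 log units; within the scatter) from compound 1 to compound 3 and no change at the digits printed (within the scatter) from compound 2 to compound 4, 1.3-fold (0.11 log units) apart, within the scatter of two such steps. The change therefore reads alike on these two cores, but neither step lies beyond the scatter, so the pairs do not show that the methyl shifts the number on either core, and two cores give no rule for the whole series.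

The compounds shown leave open whether a hydroxyl, an amine, a carboxylic acid or a longer chain in place of the methyl would give a step beyond the scatter. They also leave open how the methyl would read on a third core.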